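This account rests on a few compounds, and the source may have more. Where it says the series, first, only, none or still open, it means among the compounds named here.

In a functional assay on HCT-116 cells (Homo sapiens) for antiproliferative activity, read by MTT assay, with a stated time of 48 h (a higher number here means a weaker inhibitor of growth, a lower number a stronger inhibitor of growth), compound 1 `Cc1ccc(-c2cnc(N(Cc3ccccc3)Cc3ccc(C(=O)NO)cc3)s2)cc1` gives 48800 nM, compound 2 `CCCCCCCCN(Cc1ccc(C(=O)NO)cc1)c1ncc(-c2ccc(C)cc2)s1` gives 6500 nM and compound 3 `Cc1ccc(OCCCCN(Cc2ccc(C(=O)NO)cc2)c2ncc(-c3ccc(C)cc3)s2)cc1` gives 580 nM, the lowest of the three numbers. Compound 4 `CCCCCCN(Cc1ccc(C(=O)NO)cc1)c1ncc(-c2ccc(C)cc2)s1` differs from compound 3 by a single change, (ethyl in place of 4-methylphenoxy on a saturated chain carbon, four bonds along the chain from a nitrogen on an aromatic ring). The measured step closest to this is an 11-fold lower number from compound 2 to compound 3 (1.05 log units; beyond the scatter), where 4-methylphenoxy took the place of butyl at the same chain carbon. The other two steps, a 7.5-fold lower number from compound 1 to compound 2 (0.88 log units; beyond the scatter) and an 84-fold lower number from compound 1 to compound 3 (1.92 log units; beyond the scatter), show that the number also moves with the whole chain. Among the compounds with values here, compound 4 carries ethyl where compound 2 carries butyl, and no measured step covers that difference. A large move to a higher number is therefore expected, of about the size of the step to compound 3 but reversed. The expected change is an 8.6-fold higher number from compound 3 to compound 4 (0.94 log units; beyond the scatter). For compound 4 the estimated value is 5000 nM, with an expected range of 1800 nM to 14000 nM.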

Compound 4, concentration for 50% growth inhibition: 4850 nM
For compound 4 the middle estimate is 1.0-fold (0.01 log units) above the measured one; measured number inside the range.
By their numbers in this assay, from the lowest: compound 3; then compounds 4 and 2 (each within the scatter of the next); then compound 1.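

Ethyl in place of 4-methylphenoxy gives an 8.4-fold higher number from compound 3 to compound 4 (0.92 log units; beyond the scatter) in this assay, so the terminal 4-methylphenoxy matters at this chain carbon. Between the two plain chains the step is a 1.3-fold lower number from compound 2 to compound 4 (0.13 log units; within the scatter), which leaves their lengths unseparated and ties the low number of compound 3 to the 4-methylphenoxy end, not to chain length. Pentyl in place of phenyl gives a 10-fold lower number from compound 1 to compound 4 (1.00 log units; beyond the scatter), so a plain chain already carries part of the gain over the phenyl group.

Nothing at hand explains these steps. As far as these compounds go, whether an amine or a carboxylic acid at the chain end would keep the gain stays open.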